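This account rests on a few compounds, and the source may have more. Where it says the series, first, only, none or still open, it means among the compounds named here.

Measured so far in an ADME assay on WI-38 cells (Homo sapiens) for cytotoxicity, read by MTT assay, with a stated time of 72 h; on this read-out lower numbers stand for stronger inhibition and higher numbers for weaker inhibition:
compound 1 `O=C(O)CCc1cccc2c1B(O)OC2` – a limit only, > 100000 nM
compound 2 `O=C(CCc1cccc2c1B(O)OC2)Nc1ccccc1` – 30000 nM
compound 3 `CC(C)(C)OC(=O)NCc1ccc(NC(=O)CCc2cccc3c2B(O)OC3)cc1` – 4800 nM

Compound 2 holds the highest of the two numbers in this assay ; its nearest neighbour is compound 3, reached by a 6.3-fold lower number from compound 2 to compound 3 (0.80 log units; beyond the scatter) with ((tert-butoxycarbonyl)amino)methyl in place of hydrogen on an aromatic carbon. Compound 1 sits at a limit of this assay (the limit of > 100000 nM in this assay, at which 1 of the 3 values shown sits).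

Compound 4 `N#Cc1cccc(-c2cccc(NC(=O)CCc3cccc4c3B(O)OC4)c2)c1` differs from compound 2 by 3-cyanophenyl in place of hydrogen on an aromatic carbon. Among the measured compounds shown here, the step that bears on it is the one to compound 3, in which a group entered on an aromatic carbon of compound 2 and the number fell modestly ; the earlier step of an at least 3.3-fold lower number from compound 1 to compound 2 (0.52 log units; beyond the scatter) also lowered the number. A modest downward step is therefore expected, a 5.0-fold lower number from compound 2 to compound 4 (0.70 log units; beyond the scatter). Compound 4 is estimated at 6000 nM, between 2000 nM and 20000 nM.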

Compound 4, half-maximal inhibitory concentration: 7300 nM
For compound 4 the middle estimate is 1.2-fold (0.09 log units) below the measured one, and the stated range covers the measured number.
By their numbers in this assay, from the lowest: compounds 3 and 4 (each within the scatter of the next); then compound 2. At a limit, above all of these: compound 1.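

In this assay, 3-cyanophenyl meta to a large group lowers the number: a 4.1-fold lower number from compound 2 to compound 4 (0.61 log units; beyond the scatter). Compound 4 thus gives a second case, after compound 3, of a group on an aromatic carbon of compound 2 lowering the number, with neither of the two going against this. Nothing measured here accounts for the size of this step.

As far as these compounds go, whether a small group at this place, such as an amine or a carboxylic acid, also lowers the number stays open. So does whether the nitrile of compound 4 contributes anything beyond the added phenyl ring.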